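A few compounds are considered here, and "the series" means these few. Any claim that something is new, unique, unknown or untested is made for them only; others in the source may bear on it.

Measured so far in a functional assay on NCI-H460 cells (Homo sapiens) for antiproliferative activity, read by CCK-8 assay, with a stated time of 72 h, tested at 8 uM; on this read-out higher numbers stand for a stronger effect at the one concentration tested and lower numbers for a weaker effect:
- compound 1, `Cc1ccc(Nc2nc(Cl)nc3c2ncn3Cc2ccc(C(=O)Nc3ccccc3N)cc2)cc1`: 82.5%
- compound 2, `Cc1ccc(Nc2nc(Cl)nc3c2ncn3Cc2ccc(/C=C/C(=O)Nc3ccccc3N)cc2)cc1`: 51.3%

Within the data shown here, compound 2 stands lowest of the two numbers in this assay; its nearest neighbour is compound 1, and the only measured step runs a number 31.2 percentage points lower from compound 1 to compound 2 (beyond the scatter). That step concerns the linker between the benzyl ring and the (2-aminophenyl)carbamoyl group and nothing else.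

Compound 3, `Nc1ccccc1NC(=O)/C=C/c1ccc(Cn2cnc3c(Nc4ccccc4)nc(Cl)nc32)cc1`, is not yet measured. It differs from compound 2 at the other end of the molecule: hydrogen in place of methyl on an aromatic carbon. Among the measured compounds shown here, no measured step touches this methyl, so nothing in the two values shown speaks for or against a shift here. For the measured compounds named here, the only guide is the position of compound 2 itself, and the expectation is a step that stays within the scatter, in no particular direction. The estimated step is a number 2.3 percentage points lower from compound 2 to compound 3 (within the scatter). Compound 3 is therefore expected to give about 49% in this assay, with a range from 33% to 65%.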

Compound 3, a percentage reported as inhibition, at one concentration (the size of the read-out at that concentration, not a potency): 28.7%
The estimate for compound 3 lay 20.3 percentage points above the measured number; measured number outside the range, below it.
By their numbers in this assay, from the lowest: compound 3; then compound 2; then compound 1.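

In this assay, the methyl at this position, para to a large group, proves not to be a silent substituent: a number 22.6 percentage points lower from compound 2 to compound 3 (beyond the scatter), so the (4-methylphenyl)amino and anilino groups are not interchangeable when the ethenyl linker is present. The linker is therefore no longer the only part of the series shown to move this read-out, and a single methyl on the aromatic ring is enough to produce a step beyond the scatter. Nothing available bears on the reason for this step.

The compounds shown leave open whether replacing methyl with hydrogen gives a similar step with the direct (2-aminophenyl)carbamoyl attachment of compound 1. They also leave open whether an ethyl, a methoxy or a chlorine atom at this position would match the methyl or go beyond it.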